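This account rests on a few compounds, and the source may have more. Where it says the series, first, only, none or still open, it means among the compounds named here.

In a functional assay on NCI-H1650 cells (Homo sapiens) for cytotoxicity, read by MTT assay, with a stated time of 72 h (on this read-out lower numbers stand for stronger inhibition and higher numbers for weaker inhibition), three compounds have been measured so far. Compound 1 (`COc1ccc(/C=C2\CNC/C(=C\c3ccc(OC)c(OC)c3)C2=O)cc1OC`) gives 16700 nM, compound 3 (`CCCN1C/C(=C\c2ccc(OC)c(OC)c2)C(=O)/C(=C/c2ccc(OC)c(OC)c2)C1`) gives 16000 nM, and compound 2 (`COc1cc(/C=C2\CNC/C(=C\c3cc(OC)c(OC)c(OC)c3)C2=O)cc(OC)c1OC`) gives 4200 nM, the lowest of the three numbers and beyond the scatter from both others. Compound 4 (`CCC(=O)N1C/C(=C\c2cc(OC)c(OC)c(OC)c2)C(=O)/C(=C/c2cc(OC)c(OC)c(OC)c2)C1`) differs from compound 2 in one place: propanoyl in place of hydrogen on an amine nitrogen in a ring, with propanoyl in place of hydrogen on an amine nitrogen in a ring. For the measured compounds named here, the only measured step on this nitrogen is a 1.0-fold lower number from compound 1 to compound 3 (0.02 log units; within the scatter), within the scatter, with propyl in place of hydrogen. Propyl is not propanoyl, so this is a limited guide, and no step beyond the scatter is expected in this assay. The expected step is a 1.4-fold lower number from compound 2 to compound 4 (0.15 log units; within the scatter). For compound 4, the estimated value is 3000 nM, with an expected range of 900 nM to 9000 nM.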

Compound 4, half-maximal inhibitory concentration: 4400 nM
For compound 4 the middle estimate is 1.5-fold (0.17 log units) below the measured one; low and high end bracket the measured number.
By their numbers in this assay, from the lowest: compounds 2 and 4 (each within the scatter of the next); then compounds 3 and 1 (each within the scatter of the next).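

With a 1.0-fold higher number from compound 2 to compound 4 (0.02 log units; within the scatter) in this assay the amine nitrogen in the ring takes propanoyl on the core of compound 2 without a step beyond the scatter. For the compounds shown here, earlier, the only reading at this nitrogen was propyl on the core of compound 1 (a 1.0-fold lower number from compound 1 to compound 3 (0.02 log units; within the scatter)), so both an acyl and an alkyl group now leave the number within the scatter, each on its own core. No measurement on hand explains this result. Going by these compounds, whether propyl behaves the same way on the core of compound 2 remains open. So does the outcome with a longer chain, a benzoyl group or a chain ending in a carboxylic acid on this nitrogen.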